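The source may report more compounds than this note shows. Statements on the series, on what has been measured and on what is new or still open speak of the compounds shown alone.

Measured so far in a functional assay on OVCAR-5 cells (Homo sapiens) for inhibition, read by sulforhodamine B assay, with a stated time of 48 h; on this read-out higher numbers stand for weaker inhibition of growth and lower numbers for stronger inhibition of growth:

Compound 1 `COc1cc(-c2cc(/C=C/C(=O)c3ccc(Cl)c(Cl)c3)[nH]n2)cc(OC)c1OC`: > 100000 nM (a limit of the assay, not a number).
Compound 2 `COc1ccc(-c2cc(/C=C/C(=O)c3ccc(N)cc3)[nH]n2)cc1OC`: 7940 nM.
Compound 3 `COc1ccc(-c2cc(/C=C/C(=O)c3cc(OC)c(OC)c(OC)c3)[nH]n2)cc1OC`: 4310 nM.

The three measured compounds share a core in which a pyrazole-bearing aryl group is joined through an unsaturated chain to a carbonyl carrying a second aryl group. In this assay compound 1 gives only a limit, (the limit of > 100000 nM in this assay, at which 1 of the 3 values shown sits), so no number marks where it truly stands. Compound 2 and compound 3 both give measurable values, and the gap between them is small.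

Compound 4 `COc1ccc(C(=O)/C=C/c2cc(-c3cc(OC)c(OC)c(OC)c3)n[nH]2)cc1OC` differs from compound 1 in one place: 3,4-dimethoxyphenyl in place of 3,4-dichlorophenyl on a carbonyl carbon. Among the compounds with values here, no measured pair shows this exact change, so its size can only be expected, not read off. Since compound 1 sits at a limit, any measurable value for compound 4 would mean a step toward stronger inhibition; the expected step is an at least 16-fold lower number from compound 1 to compound 4 (1.22 log units; beyond the scatter). Compound 4 carries the same two aryl groups as compound 3, which gives 4310 nM, though attached the other way round on the core, so a value of similar size is expected. For compound 4 the estimate is 6000 nM, within 1500 nM to 30000 nM.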

Compound 4, concentration for total growth inhibition: 3030 nM
For compound 4 the middle estimate is 2.0-fold (0.30 log units) above the measured one, and the stated range covers the measured number.
By their numbers in this assay, from the lowest: compounds 4, 3 and 2 (each within the scatter of the next, the first and the last beyond it). At a limit, above all of these: compound 1.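

In this assay, within the data shown here, the change to 3,4-dimethoxyphenyl in place of 3,4-dichlorophenyl on a carbonyl carbon gives an at least 33-fold lower number from compound 1 to compound 4 (1.51 log units; beyond the scatter) and so shows, as no earlier pair could, that inhibition of growth depends strongly on the group held at this position. As far as these compounds go, the true size of this step stays unknown because compound 1 stands at a limit, not at a number: the limit of > 100000 nM in this assay, at which 1 of the 4 values shown sits. The entering group carries hydrogen-bond acceptors and the leaving group carries none, but a single pair cannot link that difference to the result.

From the compounds shown here alone, it remains open whether both methoxy groups are needed or one would do, and whether swapping only one chlorine would give part of the step. Going by these compounds, how a carboxylic acid or an unsubstituted phenyl ring would fare at this position also remains open.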